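Replacing an acetyl on compound 2

The source may report more compounds than this note shows. Statements on the series, on what has been measured and on what is new or still open speak of the compounds shown alone.

In a functional assay on SMMC-7721 cells (Homo sapiens) for cytotoxicity, read by MTT assay; on this read-out lower numbers stand for stronger inhibition and higher numbers for weaker inhibition:
Compound 1 `C/C=C(\C)C(=O)O[C@@H]1[C@@H]2OC[C@]3(C)[C@H](OC(C)=O)C[C@H](OC(C)=O)[C@@](C)([C@@H]23)[C@H]2C[C@H](OC)O[C@H]3C[C@@H](C4=CCOC4=O)C(C)=C3[C@]12C`: > 100000 nM, a limit
Compound 2 `C/C=C(\C)C(=O)O[C@@H]1[C@@H]2OC[C@]3(C)[C@H](OC(C)=O)C[C@H](O)[C@@](C)([C@@H]23)[C@H]2C[C@H](OC)O[C@H]3C[C@@H](C4=CCOC4=O)C(C)=C3[C@]12C`: 50000 nM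

Within the data shown here, compound 2, at 50000 nM, holds the only true number in this assay. Compound 3 `C/C=C(\C)C(=O)O[C@@H]1[C@@H]2OC[C@]3(C)[C@H](OC(=O)/C(C)=C/C)C[C@H](O)[C@@](C)([C@@H]23)[C@H]2C[C@H](OC)O[C@H]3C[C@@H](C4=CCOC4=O)C(C)=C3[C@]12C` differs from it by one change: 1-methylprop-1-en-1-yl in place of methyl on a carbonyl carbon, with acetyl becoming (1-methylprop-1-en-1-yl)carbonyl. Among the measured compounds shown here, the only measured step involving an acetyl is an at least 2.0-fold lower number from compound 1 to compound 2 (0.30 log units; that floor lies within the scatter), where hydrogen takes the place of acetyl, a different kind of change. Its floor lies within the scatter, so it offers little guidance. No shift beyond the scatter is therefore expected in this assay. The expected size is no change at the digits printed from compound 2 to compound 3 (within the scatter). For compound 3 the estimated value is 50000 nM, with an expected range from 20000 nM to 120000 nM.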

Compound 3, half-maximal inhibitory concentration: 50000 nM
Estimate against measurement, compound 3: no gap at the digits printed; the measured number falls inside the stated range.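

In this assay, going from acetoxy to ((1-methylprop-1-en-1-yl)carbonyl)oxy gives no change at the digits printed from compound 2 to compound 3 (within the scatter). Among these compounds, the earlier compounds all carried the acetyl here, so this is the first sign that the larger 1-methylprop-1-en-1-yl on this carbonyl carbon is accommodated without a shift beyond the scatter. Compound 1 gives only a limit, not a number: the limit of > 100000 nM in this assay, at which 1 of the 3 values shown sits.

Going by these compounds, whether a longer saturated chain or an amine on this carbonyl carbon would move the number remains open. So does whether any group here could give inhibition stronger than that of compound 2.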